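Swapping nitro for methoxy on a second core

This account rests on a few compounds, and the source may have more. Where it says the series, first, only, none or still open, it means among the compounds named here.

Compound 1 `CCCc1n[nH]c2c(=O)n(NC(=O)c3ccccc3)c(-c3cccc([N+](=O)[O-])c3)nc12`: 18.7%
Compound 2 `CCCc1n[nH]c2c(=O)n(NC(=O)c3ccccc3)c(-c3cccc(OC)c3)nc12`: 6.27%
Compound 3 `O=C(Nn1c(-c2cccc([N+](=O)[O-])c2)nc2c(-c3ccc(Cl)cc3)n[nH]c2c1=O)c1ccccc1`: 87.8%

All three numbers come from a functional assay on HT-29 cells (Homo sapiens) for cytotoxicity, read by sulforhodamine B assay, with a stated time of 2 days, tested at 100 uM; on this read-out higher numbers stand for more inhibition at the one concentration tested (going by the name of the read-out) and lower numbers for less inhibition. Compound 3 stands highest of the three, with a number 69.1 percentage points higher from compound 1 to compound 3 (beyond the scatter). The two cores differ in this way: 4-chlorophenyl in place of propyl on an aromatic carbon.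

Compound 4 `COc1cccc(-c2nc3c(-c4ccc(Cl)cc4)n[nH]c3c(=O)n2NC(=O)c2ccccc2)c1` has not been measured. It differs from compound 3 by methoxy in place of nitro on an aromatic carbon. The same change, at the same place, is already seen from compound 1 to compound 2: methoxy in place of nitro on an aromatic carbon. There it gave a number 12.4 percentage points lower from compound 1 to compound 2 (beyond the scatter).

Within the data shown here, since the places of both changes read the same word for word, the step from compound 3 to compound 4 is expected to be of a like size, resting on the one earlier step of a number 12.4 percentage points lower from compound 1 to compound 2 (beyond the scatter); a single example gives only a rough guide, so the estimate carries a wide range. The expected step is a number 13.8 percentage points lower from compound 3 to compound 4 (beyond the scatter). Compound 4 is therefore estimated to give 74%, somewhere between 52% and 90%.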

Compound 4, a percentage reported as inhibition, at one concentration (the size of the read-out at that concentration, not a potency): 87.3%
For compound 4 the middle estimate is 13.3 percentage points below the measured one, within the range that was stated.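

On the core carrying 4-chlorophenyl, methoxy in place of nitro gave a number 0.5 percentage points lower from compound 3 to compound 4 (within the scatter), while on the propyl core the same change was beyond the scatter, yet in this assay the two steps cannot be told apart: the same change on two cores in this assay, a number 12.4 percentage points lower (beyond the scatter) from compound 1 to compound 2 and a number 0.5 percentage points lower (within the scatter) from compound 3 to compound 4, 11.9 percentage points apart, within the scatter of two such steps. The other change, 4-chlorophenyl in place of propyl, gave a number 81 percentage points higher from compound 2 to compound 4 (beyond the scatter) with methoxy present, and it was large with either group, so it carried over from one core to the other: the same change on two cores in this assay, a number 69.1 percentage points higher (beyond the scatter) from compound 1 to compound 3 and a number 81 percentage points higher (beyond the scatter) from compound 2 to compound 4, 11.9 percentage points apart, within the scatter of two such steps. With only two pairs for each change, this shows agreement among these four compounds, but it does not show that the nitro-to-methoxy swap has a real effect of any fixed size, nor that either step would hold on other cores.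

From the compounds shown here alone, it remains open what an amine or a carboxylic acid would do in the place of the nitro. Going by these compounds, it is also open whether a longer chain in place of propyl, or a plain phenyl without the chlorine, would give a number nearer that of compound 1 or that of compound 3.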